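The compounds below may be only part of what the source reports. "The series", "measured", "known", "first", "only" and "open" are said of these compounds alone.

Series notes. The shared core is carried by compound 1 `O=C(/C(=C\c1c(O)cc(O)cc1O)S(=O)(=O)c1ccccc1Br)c1ccc(Br)cc1`, compound 2 `O=C(/C(=C\c1ccc(O)cc1O)S(=O)(=O)c1ccccc1Br)c1ccc(Br)cc1` and compound 3 `O=C(/C(=C\c1ccc(Br)cc1)S(=O)(=O)c1ccccc1Br)c1ccc(Br)cc1`. In a functional assay on DU-145 cells (Homo sapiens) for inhibition, read by trypan blue exclusion, with a stated time of 96 h (on this read-out lower numbers stand for stronger inhibition of growth and higher numbers for weaker inhibition of growth), compound 1 gives 50000 nM. In this assay compound 3 gives 1000 nM. For compound 2 this assay returns only a limit, > 100000 nM, a value that sits at the limit of > 100000 nM in this assay, at which 1 of the 3 values shown sits. Among the two numbers compound 1 stands highest; its nearest neighbour is compound 3, reached by a 50-fold lower number from compound 1 to compound 3 (1.70 log units; beyond the scatter). The step of an at least 2.0-fold higher number from compound 1 to compound 2 (0.30 log units; that floor lies within the scatter) stays at its floor. From compound 2 the change to compound 3 gives an at least 100-fold lower number from compound 2 to compound 3 (2.00 log units; beyond the scatter).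

Compound 4 `Cc1ccc(S/C(=C/c2c(O)cc(O)cc2O)C(=O)c2ccc(Br)cc2)cc1` is not yet measured. Relative to compound 1 the change is (4-methylphenyl)sulfanyl in place of (2-bromophenyl)sulfonyl on a double-bonded chain carbon bound to a carbonyl carbon and a double-bonded chain carbon. Within the data shown here, every measured step alters the group on a double-bonded chain carbon bound to a double-bonded chain carbon while the (2-bromophenyl)sulfonyl is kept throughout; no measured step touches the group that changes here. Compound 4 retains the 2,4,6-trihydroxyphenyl of compound 1, and the large steps of a 50-fold lower number from compound 1 to compound 3 (1.70 log units; beyond the scatter) and an at least 100-fold lower number from compound 2 to compound 3 (2.00 log units; beyond the scatter) attach to that group, so no step beyond the scatter is expected in this assay from the present change. Compound 4 is therefore expected near 50000 nM, within 15000 nM to 100000 nM. The expected step amounts to no change at the digits printed from compound 1 to compound 4 (within the scatter).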

Compound 4, concentration for 50% growth inhibition: > 100000 nM
Compound 4: only a limit was reported; the forecaster's own chance of this, stated with the estimate: 30%; middle value at least 2.0-fold (0.30 log units) away from the limit.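

In this assay compound 4 gives > 100000 nM, which is a limit and not a number. This is the first measured change at the place on a double-bonded chain carbon bound to a carbonyl carbon and a double-bonded chain carbon, and the step reads an at least 2.0-fold higher number from compound 1 to compound 4 (0.30 log units; that floor lies within the scatter): putting (4-methylphenyl)sulfanyl in place of (2-bromophenyl)sulfonyl brings no gain in growth inhibition on the 2,4,6-trihydroxyphenyl background, while a real loss can be neither shown nor excluded from a floor of this size. The reading is bounded by the top of the range in this assay, so the true size of the step stays hidden: the limit of > 100000 nM in this assay, at which 2 of the 4 values shown sit.

The change swaps the sulfur group and the ring substituents together, so the compounds shown do not separate the sulfanyl from the sulfonyl, or the methyl from the bromo, and a (4-methylphenyl)sulfonyl or a (2-bromophenyl)sulfanyl would be needed to split them. Also open, as far as these compounds go, is how this place behaves on the 4-bromophenyl background of compound 3, which gives 1000 nM and so leaves room to read a step as a number, and whether an amine or a carboxylic acid on the ring at this place would be tolerated.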